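Taking the iodo group off compound 2

A few compounds are considered here, and "the series" means these few. Any claim that something is new, unique, unknown or untested is made for them only; others in the source may bear on it.

Compound 1 `CC(=NNC(=S)Nc1cccc(F)c1)c1ccccn1`: 12 nM
Compound 2 `CC(=NNC(=S)Nc1cccc(I)c1)c1ccccn1`: 61 nM

In a functional assay on T98G cells (Homo sapiens) for cytotoxicity, read by MTT assay, with a stated time of 48 h (a lower number here means a stronger inhibitor, a higher number a weaker inhibitor), compound 2 stands highest of the two measured compounds at 61 nM. Compound 3 `CC(=NNC(=S)Nc1ccccc1)c1ccccn1` differs from compound 2 by hydrogen in place of iodo on an aromatic carbon, with hydrogen in place of iodo on an aromatic carbon. Within the data shown here, only one measured step bears on this change: a 5.1-fold higher number from compound 1 to compound 2 (0.71 log units; beyond the scatter), a modest step beyond the scatter, for iodo in place of fluoro. That single step from compound 1 suggests that losing the iodo group should bring a modest move to a lower number. The expected step is a 2.4-fold lower number from compound 2 to compound 3 (0.39 log units; beyond the scatter). For compound 3 the estimate is 25 nM, with an expected range of 8 nM to 80 nM.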

Compound 3, half-maximal inhibitory concentration: 6.8 nM
Compound 3: the middle estimate sits 3.7-fold (0.57 log units) above what was measured; the whole stated range lies above it.
By their numbers in this assay, from the lowest: compounds 3 and 1 (each within the scatter of the next); then compound 2.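

In this assay, among these compounds, hydrogen in place of iodo on this aromatic carbon gives the first direct reading of the iodo group against hydrogen (a 9.0-fold lower number from compound 2 to compound 3 (0.95 log units; beyond the scatter)). Hydrogen in place of fluoro gives a 1.8-fold lower number from compound 1 to compound 3 (0.25 log units; within the scatter) and so leaves compound 1 and compound 3 within the scatter, which means that of the two halogens shown only the iodo group sets its compound apart from hydrogen. The compounds shown offer no measured reason for this.

As far as these compounds go, whether chloro or bromo would stay with fluoro or fall with iodo remains open. So does the outcome for a methoxy group, an amine or a carboxylic acid at this place.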